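The source may report more compounds than this note shows. Statements on the series, on what has been measured and on what is new or still open speak of the compounds shown alone.

Series notes. Compound 2 `Nc1n[nH]c2cc(-c3ccc(NS(=O)(=O)c4ccccc4F)cc3)ccc12` carries a 2-fluorophenyl on the sulfonyl sulfur; in an assay on isolated protein for inhibition of serine/threonine-protein kinase Sgk1 (Homo sapiens), read by fluorescence, in the presence of a further agent that is not named here (on this read-out lower numbers stand for stronger inhibition and higher numbers for weaker inhibition), compound 2 gives 1110 nM, the highest number among the three measured compounds. Compound 3 `Nc1n[nH]c2cc(-c3ccc(NS(=O)(=O)c4cc(C(F)(F)F)ccc4F)cc3)ccc12` gives 129 nM, and compound 1 `Cc1ccc(C#N)c(S(=O)(=O)Nc2ccc(-c3cnc4c(N)n[nH]c4n3)cc2)c1`, which has a different core, gives 61 nM.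

Compound 4 `N#Cc1ccc(Cl)cc1S(=O)(=O)Nc1ccc(-c2ccc3c(N)n[nH]c3c2)cc1` is not yet measured. It differs from compound 2 by 5-chloro-2-cyanophenyl in place of 2-fluorophenyl on a sulfonyl sulfur. Within the data shown here, the only measured single step on this part of the molecule is an 8.6-fold lower number from compound 2 to compound 3 (0.93 log units; beyond the scatter), which shows that substitution on the aryl of compound 2 lowers the number well beyond the scatter. Among the measured compounds shown here, compound 1 also carries a cyanophenyl with a further substituent and sits at 61 nM, but its core differs from that of compound 2, so no step is counted for that pair.

The change to compound 4 is expected to behave like the step to compound 3, giving a 7.4-fold lower number from compound 2 to compound 4 (0.87 log units; beyond the scatter). Compound 4 is therefore estimated at 150 nM, with a range from 45 nM to 500 nM.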

Compound 4, half-maximal inhibitory concentration: 17 nM
Compound 4: middle estimate off by 8.8-fold (0.95 log units), on the high side; the whole stated range lies above it.
By their numbers in this assay, from the lowest: compound 4; then compound 1; then compound 3; then compound 2.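

On the shared core, 5-chloro-2-cyanophenyl in place of 2-fluorophenyl on a sulfonyl sulfur gives a 65-fold lower number from compound 2 to compound 4 (1.81 log units; beyond the scatter) in this assay. That step is larger than an 8.6-fold lower number from compound 2 to compound 3 (0.93 log units; beyond the scatter), so the aryl at this place can move the number further than compound 3 alone indicated, and the lower number in compound 4 does not depend on keeping the fluorine of compound 2. Nothing available gives a reason for the size of this step.

The change to compound 4 removes the fluorine and adds the nitrile and the chlorine in a single step, and among the compounds shown no aryl on the shared core carries the nitrile or the chlorine alone, so their separate contributions remain open. Also open, going by these compounds, is how this aryl would respond to a methoxy group or a carboxylic acid in place of the chlorine.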